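The source may report more compounds than this note shows. Statements on the series, on what has been measured and on what is new or still open speak of the compounds shown alone.

Three compounds share one core and differ only in the group on the nitrogen attached to it. Compound 1 `Cc1nc(Nc2ccccc2)sc1C(=O)/C=C/c1ccc(Cl)cc1` was tested in a functional assay on BGC-823 cells (Homo sapiens) for cytotoxicity, read by MTT assay; a lower number here means a stronger inhibitor, a higher number a weaker inhibitor. In that assay compound 1 gives > 25000 nM, which is a limit of the assay and not a number. Compound 2 `Cc1ccc(Nc2nc(C)c(C(=O)/C=C/c3ccc(Cl)cc3)s2)cc1` gives in this assay only a limit, > 25000 nM. Compound 3 `Cc1nc(Nc2cccc(Cl)c2)sc1C(=O)/C=C/c1ccc(Cl)cc1` gives in this assay the value > 25000 nM, again a limit. Compound 2 thus stands where the other two stand, at the limit of the assay (the limit of > 25000 nM in this assay, at which 3 of the 3 values shown sit). The steps a step that the two limits leave unreadable from compound 1 to compound 2, a step that the two limits leave unreadable from compound 1 to compound 3 and a step that the two limits leave unreadable from compound 2 to compound 3 are all unreadable, since each joins two limits.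

Compound 4 `Cc1ccc(Nc2nc(C)c(C(=O)/C=C/c3ccccc3Cl)s2)cc1` differs from compound 2 by 2-chlorophenyl in place of 4-chlorophenyl on a double-bonded chain carbon bound to a double-bonded chain carbon. Among the compounds with values here, no measured step touches that part of the core, and the steps that were measured give no readable size in any direction. The expectation for compound 4 therefore rests on compound 2 alone, whose value > 25000 nM is a limit. The step that the limit leaves unreadable from compound 2 to compound 4 is accordingly estimated as none beyond the scatter. Compound 4 is expected to give about 30000 nM in this assay, between 8000 nM and 120000 nM, most probably reported again only as a limit.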

Compound 4, half-maximal inhibitory concentration: > 25000 nM
Compound 4 gave a limit, no number (the forecaster's own chance of this, stated with the estimate: 80%); the middle value lies beyond the limit too.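

The step from compound 2 to compound 4 cannot be read, since both values are limits and not numbers, as with every compound here: the limit of > 25000 nM in this assay, at which 4 of the 4 values shown sit. The compounds shown leave open whether any change on the shared core gives a number in this assay instead of a limit.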